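This account rests on a few compounds, and the source may have more. Where it says the series, first, only, none or still open, it means among the compounds named here.

Measured compounds:
compound 1, `CC(c1ccc(OCc2c(-c3c(Cl)cccc3Cl)noc2C2CC2)nc1C(F)(F)F)N(C)c1ccc(C(=O)O)cc1`, 208 nM
compound 2, `O=C(O)c1ccccc1OCc1ccc(OCc2c(-c3c(Cl)cccc3Cl)noc2C2CC2)nc1C(F)(F)F`, 1710 nM

Of the compounds shown here, two have been measured in a functional assay on HEK293 cells for agonist activity at Bile acid receptor (Homo sapiens); a lower number here means that less compound is needed, a higher number that more compound is needed for the effect. Compound 1 gives 208 nM in this assay. Compound 2 gives 1710 nM, the higher of the two numbers, and the gap between the two values lies beyond the scatter. For the measured compounds named here, the two compounds differ in more than one place, so no single step links them; the numbers say only that more of compound 2 is needed than of compound 1.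

Compound 3, `CC(Oc1ccc(C(=O)O)cc1)c1ccc(OCc2c(-c3c(Cl)cccc3Cl)noc2C2CC2)nc1C(F)(F)F`, has not yet been measured in this assay. It differs from compound 2 in one place: 1-(4-carboxyphenoxy)ethyl in place of (2-carboxyphenoxy)methyl on an aromatic carbon. With this change the structure of compound 3 comes closer to that of compound 1 than to that of compound 2. On that ground compound 3 is expected to need less compound than compound 2, a downward step of a size beyond the scatter, a 4.3-fold lower number from compound 2 to compound 3 (0.63 log units; beyond the scatter). The estimate for compound 3 in this assay is 400 nM, with a plausible range from 120 nM to 1300 nM.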

Compound 3, half-maximal effective concentration: 189 nM
For compound 3 the middle estimate is 2.1-fold (0.33 log units) above the measured one; the measured number falls inside the stated range.
By their numbers in this assay, from the lowest: compounds 3 and 1 (each within the scatter of the next); then compound 2.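

In this assay, for the compounds shown here, putting 1-(4-carboxyphenoxy)ethyl in place of (2-carboxyphenoxy)methyl on this aromatic carbon gives a 9.0-fold lower number from compound 2 to compound 3 (0.96 log units; beyond the scatter), the first single-place step to show that the number responds to the make-up of this side chain. With 4-carboxyphenoxy in place of (4-carboxyphenyl)(methyl)amino on the branched chain carbon, the result is a 1.1-fold lower number from compound 1 to compound 3 (0.04 log units; within the scatter), so in this pair the oxygen-linked and the methylamino-linked side chains cannot be told apart in this assay. No measured evidence on the cause of either step is available here.

The step from compound 2 to compound 3 moves the carboxy group around the ring and adds a methyl group to the chain at once, so the numbers cannot divide the change between these two features; a (4-carboxyphenoxy)methyl group at this place would separate them. As far as these compounds go, it also remains open how a 3-carboxyphenoxy group, or a tetrazole in place of the carboxylic acid, would behave on the same branched chain.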